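Thiophene Replacing Benzodioxin on a TRPV1 Antagonist Core

The source may report more compounds than this note shows. Statements on the series, on what has been measured and on what is new or still open speak of the compounds shown alone.

Measured compounds:
compound 1 `CC(C(=O)NCc1ccc(C(F)(F)F)nc1-c1ccccc1F)c1ccc(NS(C)(=O)=O)c(F)c1` gives 63.3 nM
compound 2 `CC(C(=O)NCc1ccc(C(F)(F)F)nc1-c1ccc(C(C)(C)C)cc1)c1ccc(NS(C)(=O)=O)c(F)c1` gives 0.5 nM
compound 3 `CC(C(=O)NCc1ccc(C(F)(F)F)nc1-c1ccc2c(c1)OCCO2)c1ccc(NS(C)(=O)=O)c(F)c1` gives 5 nM

These three compounds share a core and differ only in the aromatic group attached to it. In an assay on CHO cells for antagonist activity at transient receptor potential cation channel subfamily V member 1 (Homo sapiens), read by FLIPR (on this read-out higher numbers stand for weaker inhibition and lower numbers for stronger inhibition), compound 3 stands second highest of the three numbers, between compound 2 and compound 1. Compound 4 `CC(C(=O)NCc1ccc(C(F)(F)F)nc1-c1ccsc1)c1ccc(NS(C)(=O)=O)c(F)c1` is not yet measured; it carries thiophen-3-yl in place of 2,3-dihydro-1,4-benzodioxin-6-yl on an aromatic carbon.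

Within the data shown here, two measured steps bear on this change. The step of a 13-fold lower number from compound 1 to compound 3 (1.10 log units; beyond the scatter) shows that swapping a single-ring aromatic group for the benzodioxin lowers the number a great deal, and the step of a 10-fold higher number from compound 2 to compound 3 (1.00 log units; beyond the scatter) shows a further large gap to the tert-butyl-bearing ring. Compound 4 returns to a single small aromatic ring, closer to compound 1 than to compound 3, so a clearly higher number is expected. The expected step is a 6.0-fold higher number from compound 3 to compound 4 (0.78 log units; beyond the scatter). Compound 4 is therefore estimated at 30 nM, with a likely range from 8 nM to 120 nM.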

Compound 4, inhibition constant: 2 nM
For compound 4 the middle estimate is 15-fold (1.18 log units) above the measured one; the whole stated range lies above it.
By their numbers in this assay, from the lowest: compound 2; then compound 4; then compound 3; then compound 1.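

At this position, next to the ring nitrogen of the shared core, this assay shows a 2.5-fold lower number from compound 3 to compound 4 (0.40 log units; beyond the scatter), so thiophen-3-yl, with 5 heavy atoms, outperforms the 10-atom 2,3-dihydro-1,4-benzodioxin-6-yl group and a larger group is not automatically better here. A single small aromatic ring is also not poor in itself: the change from 2-fluorophenyl gives a 32-fold lower number from compound 1 to compound 4 (1.50 log units; beyond the scatter), a large gap between two single-ring groups. The 4-(tert-butyl)phenyl group still gives the lowest number of the series, with a 4.0-fold higher number from compound 2 to compound 4 (0.60 log units; beyond the scatter).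

No measurement shown here explains why the groups fall in this order. As far as these compounds go, it also remains open how a thiophen-2-yl or furan-3-yl ring would compare with thiophen-3-yl at this position.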